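The compounds below may be only part of what the source reports. "The series", "measured", "known", "first", "only" and "open" are said of these compounds alone.

Measured in a functional assay on KMS-11 cells (Homo sapiens) for antiproliferative activity, read by CellTiter-Glo, with a stated time of 72 h; on this read-out lower numbers stand for stronger inhibition and higher numbers for weaker inhibition:
Compound 1 `COc1ccc(C(=O)N(Cc2ccncc2)Cc2cccc(OCCc3cccc(C(F)(F)F)c3)c2)cc1`: 8900 nM
Compound 2 `COc1ccc(C(=O)N(Cc2ccncc2)Cc2cccc(OCC3CCN(C(=O)OC(C)(C)C)CC3)c2)cc1`: 5100 nM
Compound 3 `COc1ccc(C(=O)N(Cc2ccncc2)Cc2cccc(OCCc3ccc(Br)cc3)c2)cc1`: 8400 nM

Compound 3 gives 8400 nM, within the scatter of both other compounds. Compound 4 `COc1ccc(C(=O)N(Cc2ccncc2)Cc2cccc(OCC(=O)c3cccc(Br)c3)c2)cc1` keeps the shared core and alters one side chain: (3-bromophenyl)carbonyl in place of 4-bromobenzyl on a saturated chain carbon bound to an oxygen on an aromatic ring. For the measured compounds named here, the only measured step bearing on this change is a 1.1-fold lower number from compound 1 to compound 3 (0.03 log units; within the scatter), which stays within the scatter. That step involves no carbonyl, so the data do not speak to that part of the change. Compound 2, with a different side chain, gives 5100 nM, also within the scatter of compound 3. No step beyond the scatter is therefore expected in this assay. The expected step is a 1.2-fold lower number from compound 3 to compound 4 (0.08 log units; within the scatter). For compound 4 the expected value is 7000 nM, with an estimated range from 3500 nM to 14000 nM.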

Compound 4, half-maximal inhibitory concentration: 18700 nM
Compound 4: middle estimate off by 2.7-fold (0.43 log units), on the low side; the whole stated range lies below it.
By their numbers in this assay, from the lowest: compounds 2, 3 and 1 (each within the scatter of the next); then compound 4.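

In this assay, this side chain proves sensitive to at least one change: (3-bromophenyl)carbonyl in place of 4-bromobenzyl gives a 2.2-fold higher number from compound 3 to compound 4 (0.35 log units; beyond the scatter), and in place of 3-(trifluoromethyl)benzyl it gives a 2.1-fold higher number from compound 1 to compound 4 (0.32 log units; beyond the scatter). Both steps are modest but beyond the scatter, whereas the earlier exchange of 3-(trifluoromethyl)phenyl for 4-bromophenyl stayed within it. No evidence at hand explains the rise. The carbonyl and the change from 4-bromo to 3-bromo arrive together, so their shares remain unseparated. A 3-bromobenzyl group, or a hydroxyl or an amine on that carbon, would leave the answer open as well.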